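This account rests on a few compounds, and the source may have more. Where it says the series, first, only, none or still open, it means among the compounds named here.

Within the data shown here, in a functional assay on RAW264.7 cells (Mus musculus) for inhibition, read by Griess assay, with stated times of 2 h and 24 h (on this read-out higher numbers stand for weaker inhibition and lower numbers for stronger inhibition), compound 1 `C#CCOc1cc(O)c2c(c1)O[C@H](c1ccc(OC)c(O)c1)C/C2=N\O` gives 19100 nM, the highest of the three numbers measured so far, although its gaps to compound 3 and to compound 2 both sit within the usual scatter of repeated measurements. Compound 2 `COc1ccc([C@@H]2CC(=O)c3c(O)cc(OCc4cn(Cc5ccccc5)nn4)cc3O2)cc1O` gives 11000 nM in this assay, and compound 3 `COc1ccc([C@@H]2CC(=O)c3c(O)cc(OCc4cn(Cc5cccc(C#N)c5)nn4)cc3O2)cc1O` gives 18000 nM. Among the measured compounds shown here, the only measured single change is a 1.6-fold higher number from compound 2 to compound 3 (0.21 log units; within the scatter), which moved the number little. Compound 4 `COc1ccc([C@@H]2C/C(=N\O)c3c(O)cc(OCc4cn(-c5ccccc5)nn4)cc3O2)cc1O` differs from compound 1 in one place: 1-phenyl-1H-1,2,3-triazol-4-yl in place of ethynyl on a saturated chain carbon bound to an oxygen on an aromatic ring. For the measured compounds named here, no measured pair shows exactly this change. Compounds 2 and 3 carry a related triazole, but their core holds a carbonyl where compounds 1 and 4 hold an oxime, so their numbers serve only as a loose guide. Because compound 2 gives 11000 nM and compound 3 gives 18000 nM, compound 4 is expected to land near those numbers. The expected step of a 1.6-fold lower number from compound 1 to compound 4 (0.20 log units; within the scatter) lies at the edge of the scatter. The estimate for compound 4 in this assay is 12000 nM, with a likely range from 5000 nM to 30000 nM.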

Compound 4, half-maximal inhibitory concentration: 6130 nM
For compound 4 the middle estimate is 2.0-fold (0.29 log units) above the measured one; measured number inside the range.
By their numbers in this assay, from the lowest: compounds 4, 2, 3 and 1 (each within the scatter of the next, the first and the last beyond it).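

In this assay, among these compounds, 1-phenyl-1H-1,2,3-triazol-4-yl in place of ethynyl gives a 3.1-fold lower number from compound 1 to compound 4 (0.49 log units; beyond the scatter), a modest change, but the first single change here that clears the scatter. This shows that the position, a saturated chain carbon bound to an oxygen on an aromatic ring, can take a far larger group, with 11 heavy atoms instead of 2 and two aromatic rings, and that inhibition gets stronger rather than weaker. No measurement at hand explains why the number fell.

On these data alone, it remains open whether the triazole ring, the phenyl ring or the two together account for the step. A methyl in place of the phenyl on the triazole, or an amine or a carboxylic acid on the phenyl ring, would help separate these possibilities.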